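Phenyl in place of ethyl: half-life working notes

The compounds below may be only part of what the source reports. "The series", "measured", "known", "first", "only" and "open" are said of these compounds alone.

In an ADME assay on the whole organism (strain 129/SvEvBrd x C57BL/6) for metabolic stability, with Mus musculus as the target (a higher number here means that the compound lasts longer, a lower number that the compound disappears faster), compound 1 `CC(=O)c1nc([C@@H](O)[C@H](O)[C@H](O)CO)c(C)[nH]1` gives 6.2 h and compound 2 `CCc1[nH]c(C(C)=O)nc1[C@@H](O)[C@H](O)[C@H](O)CO` gives 2.8 h, leaving compound 2 with the lower of the two numbers. The unmeasured compound 3 `CC(=O)c1nc([C@@H](O)[C@H](O)[C@H](O)CO)c(-c2ccccc2)[nH]1` carries phenyl in place of ethyl on an aromatic carbon. Among the measured compounds shown here, the only measured step that bears on this change is a 2.2-fold lower number from compound 1 to compound 2 (0.35 log units; beyond the scatter), a modest step beyond the scatter, made by methyl in place of hydrogen on a saturated chain carbon bound to an aromatic carbon. For the measured compounds named here, no compound with an aromatic ring at this place has a measured half-life, so the direction rests on that single step. A further modest fall is expected, although a result within the scatter of compound 2 would not be surprising. The estimated step is a 1.4-fold lower number from compound 2 to compound 3 (0.15 log units; within the scatter). In this assay the expected half-life of compound 3 is 2 h, with an estimated range of 0.7 h to 5.5 h.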

Compound 3, half-life: 1.9 h
Compound 3: middle estimate off by 1.1-fold (0.02 log units), on the high side; measured number inside the range.
By their numbers in this assay, from the lowest: compounds 3 and 2 (each within the scatter of the next); then compound 1.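

In this assay, the first aromatic ring at this place gives a 1.5-fold lower number from compound 2 to compound 3 (0.17 log units; within the scatter), so the half-life does not separate phenyl from ethyl on this aromatic carbon. Measured against methyl, the same ring gives a 3.3-fold lower number from compound 1 to compound 3 (0.51 log units; beyond the scatter); among the three compounds, methyl at this place stands highest, with both compound 2 and compound 3 beyond the scatter of compound 1, and no compound shown goes against this. No measurement at hand accounts for these numbers.

The compounds shown leave open how a hydrogen, a longer chain such as butyl, or a phenyl bearing a carboxylic acid would behave at this place. They also leave open whether the gap between methyl and the two larger groups would persist with an amide in place of the acetyl group.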